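The source may report more compounds than this note shows. Statements on the series, on what has been measured and on what is new or still open speak of the compounds shown alone.

Compound 1 `Cc1cnc(Nc2ccc([N+](=O)[O-])cc2)nc1Nc1nc2ccccc2s1`, compound 2 `NS(=O)(=O)c1ccc(Nc2nccc(Nc3nc4ccccc4s3)n2)cc1` and compound 3 `Cc1cnc(Nc2ccc(S(C)(=O)=O)cc2)nc1Nc1nc2ccc(Cl)cc2s1` share a common core and differ in the groups carried on their outer rings. In a functional assay on HCT-116 cells (Homo sapiens) for antiproliferative activity, read by MTT assay, with a stated time of 48 h (a higher number here means a weaker inhibitor, a lower number a stronger inhibitor), compound 1 gives 6330 nM, compound 2 gives 5170 nM and compound 3 gives 2500 nM. Compound 1 carries the highest number of the three. Its value and that of compound 2 lie within the scatter of each other, while compound 3 sits further away, beyond the scatter. Compound 4 `Cc1cnc(Nc2ccc(F)cc2)nc1Nc1nc2ccccc2s1` differs from compound 1 in a single place: fluoro in place of nitro on an aromatic carbon. Among the measured compounds shown here, no measured pair shows a change of this kind. The step is therefore expected to be small, a 1.3-fold lower number from compound 1 to compound 4 (0.10 log units; within the scatter), in no direction beyond the scatter. Compound 4 is expected to give about 5000 nM, within a range from 1500 nM to 15000 nM.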

Compound 4, half-maximal inhibitory concentration: > 50000 nM
Compound 4: a limit, no number; the forecaster's own chance of this, stated with the estimate: 5%; middle value at least 10-fold (1.00 log units) from the limit.
By their numbers in this assay, from the lowest: compound 3; then compounds 2 and 1 (each within the scatter of the next). At a limit, above all of these: compound 4.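

Compound 4 gives no number in this assay, only a limit: the limit of > 50000 nM in this assay, at which 1 of the 4 values shown sits. Fluoro in place of nitro gives an at least 7.8-fold higher number from compound 1 to compound 4 (0.89 log units; beyond the scatter), the first single-place step seen here, so this one group on the outer six-membered ring can decide whether a number can be read at all. The earlier compounds shown here differ in more than one place and could not show this. On these data alone, one pair cannot tell whether the change comes from losing nitro or from gaining fluoro, and the cause stays open. An amine or a methoxy group at this same position would show how other groups fare there.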